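This account rests on a few compounds, and the source may have more. Where it says the series, first, only, none or still open, it means among the compounds named here.

Compound 1 `CC(C)(C)N1C[C@H](C(=O)Nc2ccc(Cl)cc2)[C@@H](c2ccc(/C=C/C(=O)Nc3ccccc3N)cc2)C1` gives 20 mL/min/kg
Compound 2 `Nc1ccccc1NC(=O)/C=C/c1ccc([C@H]2CN(Cc3ccccc3)C[C@@H]2C(=O)Nc2ccc(Cl)cc2)cc1` gives 81 mL/min/kg

In an in vitro ADME assay on microsomes from liver (Mus musculus) for pharmacokinetics, read by LC-MS, with a stated time of 10 min, tested at 1 uM (on this read-out lower numbers stand for slow clearance and higher numbers for fast clearance), compound 2 at 81 mL/min/kg holds the higher of the two numbers. Compound 3 `Nc1ccccc1NC(=O)/C=C/c1ccc([C@H]2CN(C3CCOCC3)C[C@@H]2C(=O)Nc2ccc(Cl)cc2)cc1` carries oxan-4-yl in place of benzyl on an amine nitrogen in a ring and has not yet been measured. Going by the values given here, one measured step bears on this change, with benzyl in place of tert-butyl on that nitrogen: a 4.1-fold higher number from compound 1 to compound 2 (0.61 log units; beyond the scatter) is a modest rise. Among the compounds with values here, compound 3 no longer has the benzyl, so part of that rise may be reversed, although no compound with oxan-4-yl has a measured value. The expected step in this assay is a 2.5-fold lower number from compound 2 to compound 3 (0.40 log units; beyond the scatter) and would lie beyond the scatter. For compound 3 the estimated value is 32 mL/min/kg with an expected range from 14 mL/min/kg to 70 mL/min/kg in this measurement.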

Compound 3, clearance: 44 mL/min/kg
The estimate for compound 3 lay 1.4-fold (0.14 log units) below the measured number, within the range that was stated.
By their numbers in this assay, from the lowest: compound 1; then compounds 3 and 2 (each within the scatter of the next).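

In this assay the change from benzyl to oxan-4-yl on the amine nitrogen in a ring gives a 1.8-fold lower number from compound 2 to compound 3 (0.27 log units; within the scatter) and so does not separate these two groups. Oxan-4-yl in place of tert-butyl gives a 2.2-fold higher number from compound 1 to compound 3 (0.34 log units; beyond the scatter) and so tert-butyl in compound 1 is the only one of the three groups whose steps to both others lie beyond the scatter. No evidence at hand accounts for these numbers. Going by these compounds, whether isopropyl, cyclohexyl or acetyl on this nitrogen would give a number as low as that of compound 1 remains open.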